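Replacing the oxolan-2-yl group with 2,3-dihydroxypropyl

A few compounds are considered here, and "the series" means these few. Any claim that something is new, unique, unknown or untested is made for them only; others in the source may bear on it.

Compound 1 `O=C1c2c[n+]([O-])c3ccccc3c2C(=O)c2c1c1ccccc1n2CCCCn1ccnc1` gives 170 nM
Compound 2 `CC1(C)OC[C@H](Cn2cc(Cn3c4c(c5ccccc53)C(=O)c3c[n+]([O-])c5ccccc5c3C4=O)nn2)O1` gives 340 nM
Compound 3 `O=C1c2c[n+]([O-])c3ccccc3c2C(=O)c2c1c1ccccc1n2Cc1cn([C@H]2C[C@H](O)[C@@H](CO)O2)nn1` gives 350 nM

In a functional assay on A549 cells (Homo sapiens) for cytotoxicity, read by MTT assay, with a stated time of 72 h (a lower number here means a stronger inhibitor, a higher number a weaker inhibitor), compound 3 stands level with compound 2 within the scatter, while its number lies above that of compound 1, beyond the scatter. The next structure is compound 4 `O=C1c2c[n+]([O-])c3ccccc3c2C(=O)c2c1c1ccccc1n2Cc1cn(C[C@@H](O)CO)nn1` with 2,3-dihydroxypropyl in place of 4-hydroxy-5-(hydroxymethyl)oxolan-2-yl on an aromatic nitrogen. For the measured compounds named here, the only measured step at this place is a 1.0-fold higher number from compound 2 to compound 3 (0.01 log units; within the scatter) and it also exchanges the substituent on that nitrogen. It is a single step, and no open-chain diol has been measured yet, so the support is thin. On this evidence no step beyond the scatter is expected in this assay for the new change. The estimated step is a 1.1-fold lower number from compound 3 to compound 4 (0.04 log units; within the scatter) and it would leave the series where it stands. The estimate for compound 4 is 320 nM with 150 nM to 700 nM as the expected range.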

Compound 4, half-maximal inhibitory concentration: 390 nM
Estimate against measurement, compound 4: 1.2-fold (0.09 log units) below, within the range that was stated.
By their numbers in this assay, from the lowest: compounds 1, 2, 3 and 4 (each within the scatter of the next, the first and the last beyond it).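

In this assay, 2,3-dihydroxypropyl in place of 4-hydroxy-5-(hydroxymethyl)oxolan-2-yl gives a 1.1-fold higher number from compound 3 to compound 4 (0.05 log units; within the scatter), and 1,2-dihydroxyethyl in place of 2,2-dimethyl-1,3-dioxolan-4-yl gives a 1.1-fold higher number from compound 2 to compound 4 (0.06 log units; within the scatter), so an open chain with no ring reads level with both ring-bearing substituents at this position. For the compounds shown here, the one step beyond the scatter is modest and comes from the larger exchange of 3-(1H-imidazol-1-yl)propyl for 1-(2,3-dihydroxypropyl)-1H-1,2,3-triazol-4-yl, a 2.3-fold higher number from compound 1 to compound 4 (0.36 log units; beyond the scatter). No supporting data are available to account for the flat readings at this nitrogen or for this gap.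

As far as these compounds go, whether this flat response extends to a primary amine, a carboxylic acid or a longer alkyl chain on the same nitrogen remains open. The compounds shown also do not separate the contribution of the imidazole-bearing chain from that of the triazole-bearing one.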